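A few compounds are considered here, and "the series" means these few. Any claim that something is new, unique, unknown or untested is made for them only; others in the source may bear on it.

Working notes on the series.

The shared core carries a basic side chain and a ring amine; compound 2 `CCN1CCN(CCCn2cnc3c(N4CCN(CC)CC4)nc(N)nc32)CC1` bears an ethyl on that ring amine and an amino on the aromatic carbon. In an assay on HEK293 cells for antagonist activity at Toll-like receptor 9 (Homo sapiens), read by spectrophotometry (a higher number here means a weaker inhibitor, a lower number a stronger inhibitor), compound 2 gives 260 nM, the lowest of the two numbers shown. Compound 3 `CCN1CCN(CCCn2cnc3c(N4CCN(CC)CC4)nc(N4CCCC4)nc32)CC1` gives 500 nM in this assay, and the step of a 1.9-fold higher number from compound 2 to compound 3 (0.28 log units; within the scatter) stays within the scatter, so the two sit together. Compound 1 `CCN1CCN(CCCn2cnc3c(N4CCN(C(=O)C5CCCC5)CC4)nc(NCc4ccc(OC)cc4)nc32)CC1` carries the cyclopentylcarbonyl on the ring amine together with a methoxybenzylamino on the aromatic carbon, and in this assay compound 1 reaches only a limit, > 30000 nM.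

Compound 4 `CCN1CCN(CCCn2cnc3c(N4CCN(C(=O)C5CCCC5)CC4)nc(N)nc32)CC1` is compound 2 with one change: cyclopentylcarbonyl in place of ethyl on an amine nitrogen in a ring. Among the measured compounds shown here, no measured step covers this change on its own. Compound 1 is the only compound shown with the cyclopentylcarbonyl, and it sits at the limit (the limit of > 30000 nM in this assay, at which 1 of the 3 values shown sits), although it also differs from compound 4 at the aromatic carbon, so the weight of the two changes cannot be separated. The direction is therefore expected to be toward a higher number, and the step of a 19-fold higher number from compound 2 to compound 4 (1.28 log units; beyond the scatter) is expected to exceed the scatter. For compound 4 the estimate in this assay is 5000 nM, with a range from 1000 nM to 30000 nM.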

Compound 4, half-maximal inhibitory concentration: > 30000 nM
Compound 4 was reported as a limit; the forecaster's own chance of this, stated with the estimate: 30%; at least 6.0-fold (0.77 log units) between middle value and limit.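

In this assay, the change on the amine nitrogen in the ring can now be read alone, with the amino on the aromatic carbon kept: cyclopentylcarbonyl in place of ethyl gives an at least 110-fold higher number from compound 2 to compound 4 (2.06 log units; beyond the scatter). Compound 1 could not show this, as it carries the cyclopentylcarbonyl together with a methoxybenzylamino, whereas compound 4 shows that the cyclopentylcarbonyl is enough to reach the limit of the assay without the 4-methoxybenzyl. The step from compound 1 to compound 4 cannot be read, so any further contribution of the 4-methoxybenzyl stays hidden, and both compounds now stand at a limit: the limit of > 30000 nM in this assay, at which 2 of the 4 values shown sit.

The compounds shown leave open whether the carbonyl or the cyclopentyl ring carries the step, and an acetyl or a cyclopentylmethyl on the same nitrogen would separate the two. Also open, as far as these compounds go, is how much room this nitrogen allows without a carbonyl, which a longer chain such as n-butyl in place of ethyl would test.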